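Isopropyl for cyclopropyl on the chloro compound

The compounds below may be only part of what the source reports. "The series", "measured", "known", "first", "only" and "open" are said of these compounds alone.

Going by the values given here, in an ADME assay on the whole organism (plasma, strain Sprague-Dawley) for pharmacokinetics, with Rattus norvegicus as the target, at a dose of 10 mg/kg by the oral route (a higher number here means more compound in the circulation at the dose given, a lower number less compound in the circulation), compound 1 `N#Cc1c(N2CCC(c3ccccc3)CC2)ccn(CC2CC2)c1=O` gives 4350 ng.h/mL and compound 2 `O=c1c(Cl)c(N2CCC(c3ccccc3)CC2)ccn1CC1CC1` gives 2310 ng.h/mL, so compound 2 stands within the scatter of the only other number. That single measured step, a 1.9-fold lower number from compound 1 to compound 2 (0.27 log units; within the scatter), is chloro in place of cyano on an aromatic carbon, a different change from the next one. Compound 3 `CC(C)Cn1ccc(N2CCC(c3ccccc3)CC2)c(Cl)c1=O` differs from compound 2 by isopropyl in place of cyclopropyl on a saturated chain carbon bound to an aromatic nitrogen. Among the compounds with values here, no measured step covers this change. The expected outcome is a 1.1-fold lower number from compound 2 to compound 3 (0.02 log units; within the scatter), nothing beyond the scatter. Compound 3 is estimated at 2200 ng.h/mL, with an expected range of 900 ng.h/mL to 5000 ng.h/mL.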

Compound 3, area under the concentration-time curve: 3460 ng.h/mL
Estimate against measurement, compound 3: 1.6-fold (0.20 log units) below; the range from low to high includes it.
By their numbers in this assay, from the lowest: compounds 2, 3 and 1 (each within the scatter of the next).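

In this assay, the cyclopropylmethyl and isobutyl groups read alike on the chloro compounds (a 1.5-fold higher number from compound 2 to compound 3 (0.18 log units; within the scatter)). In this one pair, on a saturated chain carbon bound to an aromatic nitrogen, a three-membered ring and an open isopropyl are not told apart by the read-out. Nothing available explains this result.

From the compounds shown here alone, it remains open whether the two groups also read alike with the nitrile of compound 1 in place of the chloro. Going by these compounds, how a longer chain, an ether or an amine would read at this place is also open.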